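Cytotoxicity of compound 3 after an amide side-chain swap

This account rests on a few compounds, and the source may have more. Where it says the series, first, only, none or still open, it means among the compounds named here.

Measured in an ADME assay on L02 cells (Homo sapiens) for cytotoxicity, read by MTT assay, with a stated time of 48 h; a higher number here means a weaker inhibitor, a lower number a stronger inhibitor:
Compound 1 `CCn1c(C(=O)NCCCN(C)C)ccc1C(CC)(CC)c1ccc(OCC(O)C(C)(C)C)c(C)c1`: 470 nM
Compound 2 `CCn1c(C(=O)NCC(OC)OC)ccc1C(CC)(CC)c1ccc(OCC(O)C(C)(C)C)c(C)c1`: 22200 nM

Of these two, compound 2 has the higher number, at 22200 nM, and so stands as the weaker inhibitor in this assay. The next compound, compound 3 `CCn1c(C(=O)N(CCC#N)CCC#N)ccc1C(CC)(CC)c1ccc(OCC(O)C(C)(C)C)c(C)c1`, has not yet been measured. It departs from compound 2 at one place: a group of 9 heavy atoms (6 carbon, 3 nitrogen; no ring) in place of a group of 7 heavy atoms (4 carbon, 1 nitrogen, 2 oxygen; no ring), on a carbonyl carbon. Neither the leaving group nor the entering group has a ring or a net charge.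

Among the compounds with values here, only one measured step bears on this change, and it does so indirectly. That step, a 47-fold higher number from compound 1 to compound 2 (1.67 log units; beyond the scatter), is large and lies beyond the scatter, and it shows that this part of the molecule can matter. Within the data shown here, it does not involve the group entering compound 3, however, and no measured step does, so the data say little about direction. No step beyond the scatter is therefore expected, though with wide uncertainty. The expected step is a 1.5-fold lower number from compound 2 to compound 3 (0.17 log units; within the scatter). For compound 3 the estimated value is 15000 nM, with an expected range from 4000 nM to 50000 nM.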

Compound 3, half-maximal inhibitory concentration: 1700 nM
Beside the measured number, compound 3's estimate is 8.8-fold (0.95 log units) above it; measured number below the stated range.
By their numbers in this assay, from the lowest: compound 1; then compound 3; then compound 2.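

In this assay, this swap at the carbonyl carbon moves the number a long way back (a 13-fold lower number from compound 2 to compound 3 (1.12 log units; beyond the scatter)), so the high number of compound 2 does not follow simply from losing the dimethylamino-bearing chain of compound 1. Compound 1 still has the lowest number of the three, and the remaining gap is modest but beyond the scatter (a 3.6-fold higher number from compound 1 to compound 3 (0.56 log units; beyond the scatter)), which leaves the nitrile-bearing group of compound 3, with its 0 hydrogen-bond donors, nearer to compound 1 than to compound 2 on this read-out. Nothing measured here accounts for either shift.

The change to compound 3 removes the amide hydrogen and brings in the nitrile-bearing chains in one move, and the compounds shown do not separate these two parts; a single 2-cyanoethyl chain with the amide hydrogen kept would speak to that. Going by these compounds, it also remains open whether a longer chain ending in a nitrile, or a chain ending in a carboxylic acid, would stay close to compound 3 or fall back towards compound 2.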